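Methoxy for Chloro: a Step Not Yet Measured

The compounds below may be only part of what the source reports. "The series", "measured", "known", "first", "only" and "open" are said of these compounds alone.

Going by the values given here, compound 2 `O=C(CCCCCc1ccc(Cl)cc1)N1CCOC1=O` is the only compound with a number in an assay on HEK293 cells for inhibition of N-acylethanolamine-hydrolyzing acid amidase (Rattus norvegicus), read by LC-MS, with a stated time of 30 min (on this read-out lower numbers stand for stronger inhibition and higher numbers for weaker inhibition), where compound 2 gives 4600 nM. Compound 1 `O=C(CCCCCc1ccc(O)c(Cl)c1)N1CCOC1=O` reaches only the limit of the assay, > 20000 nM, in this assay. Compound 3 `COc1ccc(CCCCCC(=O)N2CCOC2=O)cc1` differs from compound 2 by methoxy in place of chloro on an aromatic carbon. Among the compounds with values here, no measured step matches this change, so the step is expected to be small, no larger than the scatter or a modest weakening, a 1.3-fold higher number from compound 2 to compound 3 (0.12 log units; within the scatter) in this assay. Compound 3 is therefore estimated at 6000 nM, with a range from 2000 nM to 25000 nM.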

Compound 3, half-maximal inhibitory concentration: > 20000 nM
Compound 3 ended at the assay's limit; the forecaster's own chance of this, stated with the estimate: 25%; at least 3.3-fold (0.52 log units) between middle value and limit.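

Going by these compounds alone, on the six-membered aromatic ring, at the place para to a large group, methoxy in place of chloro gives the first single change that can be read in this assay: an at least 4.3-fold higher number from compound 2 to compound 3 (0.63 log units; beyond the scatter). The position therefore does not treat these two groups alike, and this swap costs inhibition beyond the scatter. Only a lower bound can be put on the step, because the value of compound 3 is a limit: the limit of > 20000 nM in this assay, at which 2 of the 3 values shown sit.

Going by these compounds, whether fluoro, methyl or an amine at this place would keep a measurable number in this assay stays open. So does how a longer chain would act alongside the chloro of compound 2.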